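Removing One Methoxy Group from Compound 2

The compounds below may be only part of what the source reports. "The series", "measured", "known", "first", "only" and "open" are said of these compounds alone.

Compound 1, `COc1cc(-c2cc(/C=C/C(C)=O)[nH]n2)cc(OC)c1OC`: 20100 nM
Compound 2, `COc1cc(-c2cc(/C=C/C(=O)c3ccc(N)cc3)[nH]n2)cc(OC)c1OC`: 1600 nM
Compound 3, `COc1cc(-c2cc(/C=C/C(=O)c3ccc(Cl)c(Cl)c3)[nH]n2)cc(OC)c1OC`: 3200 nM

All three were tested in a functional assay on MCF7 cells (Homo sapiens) for inhibition, read by MTT assay, with a stated time of 48 h; a higher number here means a weaker inhibitor, a lower number a stronger inhibitor. Compound 2 gives the lowest number of the three, though its gap to compound 3 lies within the scatter, as a 2.0-fold higher number from compound 2 to compound 3 (0.30 log units; within the scatter) shows. Compound 1 stands furthest off, with a 13-fold lower number from compound 1 to compound 2 (1.10 log units; beyond the scatter) and a 6.3-fold lower number from compound 1 to compound 3 (0.80 log units; beyond the scatter) both beyond the scatter; both steps concern the group on the carbonyl carbon.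

Compound 4, `COc1ccc(-c2cc(/C=C/C(=O)c3ccc(N)cc3)[nH]n2)cc1OC`, differs from compound 2 in one place: hydrogen in place of methoxy on an aromatic carbon. Among the measured compounds shown here, no measured step touches this part of the molecule, so the measured steps give no direct guide to the size or direction of this change. Compound 4 is expected to give about 3500 nM, in the range 1000 nM to 12000 nM, which is estimated as a 2.2-fold higher number from compound 2 to compound 4 (0.34 log units; beyond the scatter).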

Compound 4, half-maximal inhibitory concentration: 1900 nM
Compound 4: middle estimate off by 1.8-fold (0.27 log units), on the high side; low and high end bracket the measured number.
By their numbers in this assay, from the lowest: compounds 2, 4 and 3 (each within the scatter of the next); then compound 1.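

Replacing the methoxy group with hydrogen on this aromatic carbon, ortho to a methoxy group and meta to a large group, gives a 1.2-fold higher number from compound 2 to compound 4 (0.07 log units; within the scatter). Among the compounds shown here, this is the first measured change at this part of the molecule, and in this pair the methoxy group can be lost with no difference that can be told from the scatter. No available measurement offers a reason for this.

From the compounds shown here alone, it remains open whether a hydroxyl, ethoxy or amine group on this carbon would give a similar number, and whether the same replacement would behave alike with the 3,4-dichlorophenyl group of compound 3.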